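A new side chain on compound 1

The source may hold more compounds than are shown below. What is called first, only, known or untested is meant among the compounds shown, and "the series" means these compounds.

Compound 1 `COc1cc(C2CN(C(=O)c3cc(OC[C@H](O)CO)ccn3)C2)ccc1OCc1ccc(C2CC2)cc1`: 2700 nM
Compound 2 `COc1cc(C2CN(C(=O)c3cc(OC[C@@H](O)CO)ccn3)C2)ccc1OCc1ccc(C2CC2)cc1`: 3100 nM

Both numbers come from a physicochemical assay for solubility, in phosphate buffer, at pH 7.2; a higher number here means a more soluble compound, a lower number a less soluble compound. Compound 1 has a single measured neighbour, compound 2, and the two cannot be told apart: the measured step, a 1.1-fold higher number from compound 1 to compound 2 (0.06 log units; within the scatter), lies within the scatter. That step comes with the fact that compounds 1 and 2 differ only in the configuration as drawn, so it speaks only to the configuration of the chain and not to the chain itself.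

Compound 3 `COc1cc(C2CN(C(=O)c3cc(COCC(CO)(CO)CO)ccn3)C2)ccc1OCc1ccc(C2CC2)cc1` keeps the shared core, but (3-hydroxy-2,2-bis(hydroxymethyl)propoxy)methyl stands in place of 2,3-dihydroxypropoxy on an aromatic carbon, opposite the ring nitrogen ((3-hydroxy-2,2-bis(hydroxymethyl)propoxy)methyl in place of 2,3-dihydroxypropoxy on an aromatic carbon). Here the whole chain is exchanged, and no measured compound shows what such an exchange does. Among the compounds with values here, the small step above is the only guide, and a weak one. In this assay the expectation is therefore no step beyond the scatter in either direction, with wide uncertainty, starting from compound 1 at 2700 nM. Expressed as a step, the estimate is a 1.3-fold higher number from compound 1 to compound 3 (0.11 log units; within the scatter). For compound 3 the estimated value is 3500 nM, with an expected range from 1000 nM to 12000 nM.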

Compound 3, solubility: 1500 nM
The estimate for compound 3 lay 2.3-fold (0.37 log units) above the measured number, and the stated range covers the measured number.
By their numbers in this assay, from the lowest: compounds 3, 1 and 2 (each within the scatter of the next, the first and the last beyond it).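

Compounds 1 and 2 spoke only to the configuration of the chain, whereas compound 3 exchanges the chain itself on this aromatic carbon, opposite the ring nitrogen. In this assay, putting (3-hydroxy-2,2-bis(hydroxymethyl)propoxy)methyl in place of 2,3-dihydroxypropoxy gives a 1.8-fold lower number from compound 1 to compound 3 (0.26 log units; within the scatter) and a 2.1-fold lower number from compound 2 to compound 3 (0.32 log units; beyond the scatter), and the entering chain, though it counts more hydrogen-bond donors and acceptors than the one that leaves, brings no higher number against either starting point. These two steps describe one and the same exchange, and the comparison between them rests on one fact: the fact that compounds 1 and 2 differ only in the configuration as drawn.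

The exchange alters the size of the chain, its branching and the way it joins the ring all at once, and these compounds cannot separate those parts from one another. They also leave open how a chain ending in an amine or a carboxylic acid, or a longer chain with a single hydroxyl, would read at this position.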